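From methoxy to sulfamoyl on one aromatic carbon

The source may hold more compounds than are shown below. What is called first, only, known or untested is meant among the compounds shown, and "the series" means these compounds.

Values measured so far in a functional assay on B16 cells (Mus musculus) for inhibition (on this read-out higher numbers stand for weaker inhibition and lower numbers for stronger inhibition), are these
Compound 1 `O=C(/C=C/c1ccc(O)c(O)c1)NCc1ccc(C(F)(F)F)cc1` gives 1600 nM 
Compound 2 `COc1ccc(CNC(=O)/C=C/c2ccc(O)c(O)c2)cc1` gives 6200 nM 

Compound 2 stands at the higher of the two numbers, which makes it the weaker inhibitor of the pair. Compound 3 `NS(=O)(=O)c1ccc(CNC(=O)/C=C/c2ccc(O)c(O)c2)cc1` carries sulfamoyl in place of methoxy on an aromatic carbon. Among the measured compounds shown here, the one measured step at this place shows a 3.9-fold higher number from compound 1 to compound 2 (0.59 log units; beyond the scatter) when methoxy replaces trifluoromethyl. For the measured compounds named here, no sulfamoyl compound has been measured, so this modest step is only a rough guide. The step expected in this assay is a 2.1-fold lower number from compound 2 to compound 3 (0.32 log units; beyond the scatter) on this estimate, a modest move toward a lower number. Compound 3 is expected to give about 3000 nM with an estimated range from 900 nM to 10000 nM in this read-out.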

Compound 3, half-maximal inhibitory concentration: > 40000 nM
Compound 3: only a limit was reported (the forecaster's own chance of this, stated with the estimate: 5%); middle value at least 13-fold (1.12 log units) away from the limit.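

In this assay, the earlier pair showed only a modest shift at this aromatic carbon, whereas sulfamoyl gives an at least 6.4-fold higher number from compound 2 to compound 3 (0.80 log units; beyond the scatter) and an at least 25-fold higher number from compound 1 to compound 3 (1.39 log units; beyond the scatter). The position is therefore more sensitive to the group it carries than trifluoromethyl and methoxy alone revealed. The value of compound 3 is a limit, not a number: the limit of > 40000 nM in this assay, at which 1 of the 3 values shown sits.

Going by these compounds, it remains open whether an amine or a carboxylic acid on this carbon would track sulfamoyl or the two earlier groups. The data also do not tell which feature of sulfamoyl accounts for the change.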